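This account rests on a few compounds, and the source may have more. Where it says the series, first, only, none or still open, it means among the compounds named here.

Of the compounds shown here, two with a shared core have been measured in a functional assay on A549 cells (Homo sapiens) for antiproliferative activity, read by MTT assay, with a stated time of 48 h; a higher number here means a weaker inhibitor, a lower number a stronger inhibitor. Compound 1 `Clc1cccc(Nc2ncnc3ccc(NCc4cccs4)cc23)c1` gives 2080 nM, and compound 2 `O=C(/C=C/c1cccc(Br)n1)Nc1ccc2ncnc(Nc3cccc(Cl)c3)c2c1` gives 4160 nM, so the two values sit within the usual scatter of each other. Compound 3 `O=C(/C=C/c1cccs1)Nc1ccc2ncnc(Nc3cccc(Cl)c3)c2c1` differs from compound 2 in one place: thiophen-2-yl in place of 6-bromopyridin-2-yl on a double-bonded chain carbon bound to a double-bonded chain carbon. For the measured compounds named here, no measured pair shows this change directly, so the step from compound 2 to compound 3 is expected to be small, at most a modest gain, and is estimated as a 1.4-fold lower number from compound 2 to compound 3 (0.14 log units; within the scatter). Compound 3 is expected to give about 3000 nM in this assay, within a range from 1000 nM to 9000 nM.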

Compound 3, half-maximal inhibitory concentration: 9310 nM
Beside the measured number, compound 3's estimate is 3.1-fold (0.49 log units) below it, and the stated range ends below it.
By their numbers in this assay, from the lowest: compounds 1 and 2 (each within the scatter of the next); then compound 3.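

Putting thiophen-2-yl in place of 6-bromopyridin-2-yl on a double-bonded chain carbon bound to a double-bonded chain carbon gives a 2.2-fold higher number from compound 2 to compound 3 (0.35 log units; beyond the scatter), so the ring at this position does affect the number. With a thiophen-2-yl group in both compounds, the different link on a nitrogen on an aromatic ring gives a 4.5-fold higher number from compound 1 to compound 3 (0.65 log units; beyond the scatter). No measured evidence explains either step.

From the compounds shown here alone, this change swaps the ring and removes the bromine together, so their separate contributions remain unknown. A plain pyridin-2-yl or phenyl group at this position could help to separate them.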